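Acetyl for hydrogen on the aniline nitrogen of compound 2

The source may hold more compounds than are shown below. What is called first, only, known or untested is meant among the compounds shown, and "the series" means these compounds.

Measured so far in an assay on isolated protein for inhibition of phosphoenolpyruvate carboxykinase, cytosolic [GTP] (Homo sapiens); on this read-out higher numbers stand for weaker inhibition and lower numbers for stronger inhibition:
- compound 1 `CCCCn1c(=O)n(Cc2ccccc2F)c(=O)c2[nH]c(Cc3ccc(NC(=O)C(F)(F)F)cc3)nc21`: 2300 nM
- compound 2 `CCCCn1c(=O)n(Cc2ccccc2F)c(=O)c2[nH]c(Cc3ccc(N)cc3)nc21`: 2560 nM
- compound 3 `O=c1c2[nH]c(Cc3ccc(NS(=O)(=O)c4cccnc4)cc3)nc2n(CC2CC2)c(=O)n1Cc1ccccc1F`: 1950 nM

Compound 2 carries the free amino group and gives the largest of the three numbers, yet all three lie within the scatter of one another, so no order among compound 1, compound 2 and compound 3 can be read from them. Going by the values given here, the one single-point step available is a 1.1-fold higher number from compound 1 to compound 2 (0.05 log units; within the scatter), which shows that removing the (trifluoromethyl)carbonyl from the nitrogen leaves this assay essentially unchanged.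

The unmeasured compound 4 `CCCCn1c(=O)n(Cc2ccccc2F)c(=O)c2[nH]c(Cc3ccc(NC(C)=O)cc3)nc21` differs from compound 2 by acetyl in place of hydrogen on a nitrogen on an aromatic ring. This is the same position that was varied between compound 1 and compound 2, and there the carbonyl substituent versus hydrogen made no difference beyond the scatter. By analogy, acetyl on that nitrogen is expected to give no step beyond the scatter in this assay; the estimated step is a 1.1-fold lower number from compound 2 to compound 4 (0.05 log units; within the scatter). For compound 4 the expected value is 2300 nM, with a range from 1000 nM to 5000 nM.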

Compound 4, half-maximal inhibitory concentration: 2110 nM
For compound 4 the middle estimate is 1.1-fold (0.04 log units) above the measured one, and the stated range covers the measured number.
By their numbers in this assay, from the lowest: compounds 3, 4, 1 and 2 (each within the scatter of the next).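

In this assay, going by these compounds alone, acetyl on the nitrogen gives a 1.2-fold lower number from compound 2 to compound 4 (0.08 log units; within the scatter), so a second acyl group now joins the (trifluoromethyl)carbonyl in showing no step from the free amino group beyond the scatter. The change within the acyl group, methyl in place of trifluoromethyl on a carbonyl carbon, gives a 1.1-fold lower number from compound 1 to compound 4 (0.04 log units; within the scatter), which adds a comparison between two acyl groups to the earlier one against hydrogen alone. Nothing available accounts for this insensitivity.

From the compounds shown here alone, whether a larger acyl group on this nitrogen, such as benzoyl or a longer chain, or one bearing a carboxylic acid, would also stay within the scatter remains open. Compound 3 differs from the others in more than one place, so a methanesulfonyl on the nitrogen of the butyl series would be needed to read a sulfonyl group at this position in one step.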